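Replacing a hydroxyethyl amide with a methoxy-bicyclic group

The source may hold more compounds than are shown below. What is called first, only, known or untested is meant among the compounds shown, and "the series" means these compounds.

Of the compounds shown here, three from this series have been measured in an ADME assay for permeability; a higher number here means that the compound crosses the layer faster, a lower number that the compound crosses the layer more slowly. Compound 1 `CNC(=O)c1cc(C(=O)NC2CC2)cn([C@H](C)c2ccccc2)c1=O` gives 160 nm/s, compound 2 `CNC(=O)c1cc(C(=O)NCCO)n([C@@H](C)c2ccccc2)n1` gives 59 nm/s, and compound 3 `CNC(=O)c1cc(C(=O)N[C@H]2CC[C@H](O)CC2)n([C@@H](C)c2cccc(C)c2)n1` gives 110 nm/s. Compound 2 stands at the lowest of the three numbers; its gap to compound 3 lies within the usual scatter, while its gap to compound 1 lies beyond it.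

Compound 4 `CNC(=O)c1cc(C(=O)N[C@H]2[C@@H]3C[C@@H](OC)C[C@@H]32)n([C@@H](C)c2ccccc2)n1` has not yet been measured in this assay. Relative to compound 2 the change is a group of 8 heavy atoms (7 carbon, 1 oxygen; one three-membered non-aromatic ring of carbon only, one five-membered non-aromatic ring of carbon only) in place of a group of 3 heavy atoms (2 carbon, 1 oxygen; no ring), on an amide-type nitrogen. Within the data shown here, no measured pair in this set differs by exactly this kind of exchange, so no directly comparable step is available.

Among the measured compounds shown here, the author expects the step from compound 2 to compound 4 to be upward and of a size beyond the scatter, a 3.1-fold higher number from compound 2 to compound 4 (0.48 log units; beyond the scatter), leaning on the fact that compound 1, the only compound without a hydroxyl on its amide substituent, gives 160 nm/s. For compound 4 the estimated value in this assay is 180 nm/s, with a range from 90 nm/s to 350 nm/s.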

Compound 4, apparent permeability: 440 nm/s
For compound 4 the middle estimate is 2.4-fold (0.39 log units) below the measured one; the whole stated range lies below it.
By their numbers in this assay, from the lowest: compounds 2, 3 and 1 (each within the scatter of the next, the first and the last beyond it); then compound 4.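

Among these compounds, at the amide-type nitrogen, the one place that changes, the methoxy-bicyclic group in place of 2-hydroxyethyl gives a 7.5-fold higher number from compound 2 to compound 4 (0.87 log units; beyond the scatter) in this assay. Among the compounds shown here, this is the first single-place step in the set, and it shows that this substituent alone can move the read-out beyond the scatter, although the exchange changes several things together: the entering group has more heavy atoms, two carbon rings, and 0 hydrogen-bond donors where the leaving group has 1. No evidence bearing on the cause of this step is available.

The compounds shown leave open how a 2-methoxyethyl or a plain cyclopentyl group would read on this nitrogen. The separate shares of the rings, the methoxy group and the lost hydroxyl therefore remain unresolved.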